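From 4-fluorobenzyl to (naphthalen-2-yl)methyl in compound 1

The source may hold more compounds than are shown below. What is called first, only, known or untested is meant among the compounds shown, and "the series" means these compounds.

In a functional assay on HepG2 cells (Homo sapiens) for inhibition, read by MTT assay, with a stated time of 72 h (on this read-out higher numbers stand for weaker inhibition and lower numbers for stronger inhibition), compound 1 (`O=C1/C(=C\c2ccccc2)c2c(ncn2COCc2ccccc2)CCN1Cc1ccc(F)cc1`) gives 39400 nM and sits within the scatter of compound 2 (`COc1ccc(CN2CCc3ncn(COCc4ccccc4)c3/C(=C/c3ccccc3)C2=O)cc1`) at 44400 nM in this series. Compound 3 (`CC(C)(C)c1ccc(CN2CCc3ncn(COCc4ccccc4)c3/C(=C/c3ccccc3)C2=O)cc1`) gives the lowest number of the three (18000 nM).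

Compound 4 (`O=C1/C(=C\c2ccccc2)c2c(ncn2COCc2ccccc2)CCN1Cc1ccc2ccccc2c1`) has naphthalen-2-yl in place of 4-fluorophenyl on a saturated chain carbon bound to an amide-type nitrogen in a ring.

Two steps on the aromatic carbon bear on this only indirectly. Methoxy for fluoro gave (a 1.1-fold higher number from compound 1 to compound 2 (0.05 log units; within the scatter)), and tert-butyl for fluoro gave (a 2.2-fold lower number from compound 1 to compound 3 (0.34 log units; beyond the scatter)). Neither replaces the whole aromatic group, so only a small move towards a lower number is expected.

The estimated step is (a 1.8-fold lower number from compound 1 to compound 4 (0.25 log units; within the scatter)). Compound 4 is estimated at 22000 nM (10000 nM to 48000 nM).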

Compound 4, half-maximal inhibitory concentration: 23700 nM
Beside the measured number, compound 4's estimate is 1.1-fold (0.03 log units) below it; measured number inside the range.
By their numbers in this assay, from the lowest: compounds 3, 4, 1 and 2 (each within the scatter of the next, the first and the last beyond it).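

Replacing the whole aromatic group on a saturated chain carbon bound to an amide-type nitrogen in a ring leaves every comparison within the scatter (a 1.7-fold lower number from compound 1 to compound 4 (0.22 log units; within the scatter)) (a 1.9-fold lower number from compound 2 to compound 4 (0.27 log units; within the scatter)) (a 1.3-fold higher number from compound 3 to compound 4 (0.12 log units; within the scatter)). Compound 4, with its 2 six-membered aromatic rings, therefore cannot be separated from any single-ring compound, even though compound 2 and compound 3 differ from each other beyond the scatter. Nothing at hand accounts for this result.

The compounds shown leave open whether an amine, a carboxylic acid or a longer chain at this place would move the number beyond the scatter of these four.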